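The compounds below may be only part of what the source reports. "The series", "measured", "known", "first", "only" and "open" are said of these compounds alone.

Measured compounds:
- Compound 1, `CC1=CC[C@@H]([C@@](C)(O)CCCC(C)(C)NC(=S)NN)CC1`; in a functional assay on PCO3 cells (Homo sapiens) for cytotoxicity, read by sulforhodamine B assay (a higher number here means a weaker inhibitor of growth, a lower number a stronger inhibitor of growth), compound 1 reaches only the limit of the assay, > 100000 nM.
- Compound 2, `CC1=CC[C@@H]([C@@](C)(O)CCCC(C)(C)NC(=S)N/N=C\c2ccccc2[N+](=O)[O-])CC1`; in this assay compound 2 likewise reaches only a limit, > 100000 nM.

Compound 2 therefore stands at the top of what the assay can report, the same limit that compound 1 reaches; neither value is a number. Among the compounds with values here, both values sit at the limit of > 100000 nM in this assay, at which 2 of the 2 values shown sit, so no step between measured compounds can be sized here.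

The next compound, compound 3 with `CC1=CC[C@@H]([C@@](C)(O)CCCC(C)(C)NC(=S)N/N=C\c2ccccc2Cl)CC1`, differs from compound 2 by chloro in place of nitro on an aromatic carbon. Within the data shown here, with both measured values at a limit there is no step on record from which to read the effect of this change. The expectation for compound 3 in this assay is a step from compound 2 of about a number no higher from compound 2 to compound 3 (the limit leaves the size open), most likely none beyond the scatter. Compound 3 is expected to give around 100000 nM, within the range 30000 nM to 300000 nM, most probably again only a limit.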

Compound 3, concentration for total growth inhibition: > 100000 nM
Compound 3: no number, only a limit (the forecaster's own chance of this, stated with the estimate: 75%); the middle value lies on the limit itself.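

In this assay, within the data shown here, compound 3 reaches only the limit > 100000 nM and no step from compound 1 or compound 2 to compound 3 can be read: the limit of > 100000 nM in this assay, at which 3 of the 3 values shown sit.

The compounds shown leave open whether any of them inhibits growth at a measurable concentration, and how chloro and nitro compare.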